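Removing a Nitro Group from a Pyridinylidene Thiazolidinone Series

A few compounds are considered here, and "the series" means these few. Any claim that something is new, unique, unknown or untested is made for them only; others in the source may bear on it.

Measured so far:
compound 1, `O=C1N/C(=N/c2ccccc2)S/C1=C\c1ccccn1`, 26.2%
compound 2, `Cc1ccc(/N=C2/NC(=O)/C(=C/c3ccccn3)S2)cc1`, 43.8%
compound 3, `O=C1N/C(=N/c2ccc([N+](=O)[O-])cc2Cl)S/C1=C\c1ccccn1`, 39.7%

All three share one core and differ only in the aromatic ring attached through the imine nitrogen. In a functional assay on the whole organism (strain Wistar) for inhibition, with Rattus norvegicus as the target, read by paw edema, with stated times of 30 min and 120 min, at a dose of 10 mg/kg by the oral route (a lower number here means less inhibition, a higher number more inhibition at the dose given (going by the name of the read-out)), compound 1 gives 26.2%. Among the measured compounds shown here, the single one-change step measured is a number 17.6 percentage points higher from compound 1 to compound 2 (beyond the scatter). Compound 3 gives 39.7% in this assay; it stands second highest of the three numbers, within the scatter of compound 2, and beyond the scatter above compound 1.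

Compound 4, `O=C1N/C(=N/c2ccccc2Cl)S/C1=C\c1ccccn1`, is not yet measured. It differs from compound 3 in one place: hydrogen in place of nitro on an aromatic carbon. For the measured compounds named here, no measured step concerns a nitro group; the only step known, a number 17.6 percentage points higher from compound 1 to compound 2 (beyond the scatter), concerns a methyl group instead. What can be said is that compound 1, whose ring carries no substituent, sits below compound 3, whose ring carries both chloro and nitro; compound 4 keeps the chloro group alone. A small decrease, or no step beyond the scatter, is therefore expected, as a number 6.7 percentage points lower from compound 3 to compound 4 (within the scatter). Compound 4 is estimated to give 33% in this assay, with a range from 22% to 44%.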

Compound 4, a percentage reported as inhibition, in the whole organism at one dose (the size of the read-out at that dose, not a potency): 26.2%
Compound 4: middle estimate off by 6.8 percentage points, on the high side; measured number inside the range.
By their numbers in this assay, from the lowest: compounds 1 and 4 (each within the scatter of the next); then compounds 3 and 2 (each within the scatter of the next).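

Among the compounds shown here, removing the nitro group in this assay gives a number 13.5 percentage points lower from compound 3 to compound 4 (beyond the scatter), the first sign that a group at this place, on an aromatic carbon meta to a chloro group and para to a large group, can change the read-out. The chloro group left on compound 4 shows no effect of its own, with no change at the digits printed from compound 1 to compound 4 (within the scatter), so in this pair adding chloro to the bare ring leaves the number where it was. Exchanging the rings gives a number 17.6 percentage points lower from compound 2 to compound 4 (beyond the scatter), which means that 2-chlorophenyl does not match 4-methylphenyl on the double-bonded nitrogen in this assay.

Nothing available explains why the nitro group matters here and the same gap applies to the methyl group. From the compounds shown here alone, it remains open whether an amine or a carboxylic acid at the place held by the nitro group would keep the number of compound 3, and whether a nitro group on a ring without chloro would do the same.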